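Third methoxy on the aryl ring of the lactone series

This account rests on a few compounds, and the source may have more. Where it says the series, first, only, none or still open, it means among the compounds named here.

Among the compounds with values here, compound 3 `COc1ccc(/C=C/C2CC=CC(=O)O2)cc1OC` stands second highest of the three numbers measured so far in a functional assay on U-251 cells (Homo sapiens) for inhibition, read by sulforhodamine B assay, with a stated time of 48 h; on this read-out higher numbers stand for weaker inhibition of growth and lower numbers for stronger inhibition of growth: compound 3 gives 23.9 uM. Its nearest neighbour is compound 2 `COc1ccc(/C=C/C2CC=CC(=O)O2)cc1`, which in this assay gives 20.6 uM; the furthest is compound 1 `COc1cc(/C=C/C2CC(=O)C=CO2)cc(OC)c1OC`, which in this assay gives 102 uM. Compound 1 carries the same three methoxy groups that compound 4 will carry but on a different core, so its value is noted without a computed step to any other compound.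

Compound 4 `COc1cc(/C=C/C2CC=CC(=O)O2)cc(OC)c1OC` differs from compound 3 as follows: methoxy in place of hydrogen on an aromatic carbon.

Within the data shown here, the one measured step of the same kind is a 1.2-fold higher number from compound 2 to compound 3 (0.06 log units; within the scatter). That step was within the scatter, so a single added methoxy on this aryl ring has not so far moved the number. The value of compound 1 in this assay leaves open that the three-methoxy pattern sits weaker, but with a different core this cannot be read as a step. The expectation for a 1.3-fold higher number from compound 3 to compound 4 (0.13 log units; within the scatter) is therefore a small change, if any, leaning toward a higher number.

Compound 4 is estimated at 32 uM, with a range from 12 uM to 80 uM.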

Compound 4, concentration for growth inhibition (reported as GI): 25.1 uM
Compound 4: middle estimate off by 1.3-fold (0.11 log units), on the high side; the measured number falls inside the stated range.
By their numbers in this assay, from the lowest: compounds 2, 3 and 4 (each within the scatter of the next); then compound 1.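

In this assay, the methoxy entering on an aromatic carbon ortho to a methoxy group and meta to a group of 9 heavy atoms gives a 1.1-fold higher number from compound 3 to compound 4 (0.02 log units; within the scatter) and so, alongside a 1.2-fold higher number from compound 2 to compound 3 (0.06 log units; within the scatter) on the same ring, adds a second methoxy step that leaves the number within the scatter. With the three-methoxy pattern now present on both cores, the exchange of the core of compound 1 for the shared core of compounds 2, 3 and 4 gives a 4.1-fold lower number from compound 1 to compound 4 (0.61 log units; beyond the scatter), so the high number of compound 1 cannot be placed on the three methoxy groups alone. No measurement at hand bears on why the number holds at this position or shifts with the core.

Still open, from the compounds shown here alone, is whether this position accepts groups other than methoxy with the same result, for instance a hydroxy group, an amine or a longer alkoxy chain. Also open, going by these compounds, is whether the gap between the two cores persists with one or two methoxy groups on the ring, as the core of compound 1 appears here only with three.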